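Trimming the Amide Side Chain from Compound 3 to Compound 4

The source may hold more compounds than are shown below. What is called first, only, known or untested is meant among the compounds shown, and "the series" means these compounds.

Three anilide chalcones share one core and differ only in the group on the amide carbonyl carbon. Compound 1 `COc1cc(/C=C/C(=O)c2cccc(NC(=O)c3ccc(Cl)cc3)c2)ccc1O` carries 4-chlorophenyl there and gives 42% in a functional assay on HUVEC cells (Homo sapiens) for inhibition, tested at 5 ug/mL; on this read-out higher numbers stand for a stronger effect at the one concentration tested and lower numbers for a weaker effect. Compound 2 `COc1cc(/C=C/C(=O)c2cccc(NC(=O)c3ccco3)c2)ccc1O` carries furan-2-yl and in this assay compound 2 gives 82%. Compound 3 `COc1cc(/C=C/C(=O)c2cccc(NC(=O)C(C)C)c2)ccc1O` carries isopropyl and in this assay compound 3 gives 51%.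

Among these three numbers compound 3 stands second highest. Its nearest neighbour is compound 1, with a number 9 percentage points higher from compound 1 to compound 3 (within the scatter), and its furthest is compound 2, with a number 31 percentage points lower from compound 2 to compound 3 (beyond the scatter). Going by the values given here, the one large step seen so far thus belongs to the exchange of furan-2-yl, not to a change between two alkyl groups.

Compound 4 `COc1cc(/C=C/C(=O)c2cccc(NC(C)=O)c2)ccc1O` is the next member, not yet measured. It differs from compound 3 by methyl in place of isopropyl on a carbonyl carbon. Among the compounds with values here, no measured step involves methyl, and the only step touching an alkyl group, a number 9 percentage points higher from compound 1 to compound 3 (within the scatter), stayed within the scatter. The shortening of a three-carbon chain to one carbon is therefore expected to give no step beyond the scatter in this assay; the expected step is a number 4 percentage points lower from compound 3 to compound 4 (within the scatter). For compound 4 the estimated value in this assay is 47%, with a range from 30% to 64%.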

Compound 4, a percentage reported as inhibition, at one concentration (the size of the read-out at that concentration, not a potency): 15%
For compound 4 the middle estimate is 32 percentage points above the measured one; the measured number lies below the stated range.
By their numbers in this assay, from the lowest: compound 4; then compounds 1 and 3 (each within the scatter of the next); then compound 2.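

In this assay, the alkyl groups on this carbonyl carbon are not interchangeable: methyl in place of isopropyl gives a number 36 percentage points lower from compound 3 to compound 4 (beyond the scatter), a large change from a single alkyl exchange. Methyl also falls short of both ring-bearing groups, with a number 27 percentage points lower from compound 1 to compound 4 (beyond the scatter) and a number 67 percentage points lower from compound 2 to compound 4 (beyond the scatter), so the smallest group shown here gives the lowest number of the four, though larger size does not simply track with a higher number, as compound 1 and compound 3 stay within the scatter of each other and compound 2 stands apart from both. No information is available to explain this drop.

The compounds shown leave open where the number rises along the alkyl series, since an ethyl group or a longer chain such as n-butyl would show whether isopropyl sits on a rising trend or near a plateau. They also leave open whether the high number of compound 2 is particular to furan-2-yl or would carry over to a thiophen-2-yl group, and whether an amine at the end of a chain would be tolerated at this position.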